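The compounds below may be only part of what the source reports. "The series", "measured", "known", "first", "only" and "open" are said of these compounds alone.

Compound 1 `COc1ccc2nc(C)cc(OCC(=O)Nc3ccc(Cl)c(OC)c3)c2c1`; in a toxicity assay on HepG2 cells (Homo sapiens) for inhibition, read by CellTiter-Glo, with a stated time of 48 h (on this read-out lower numbers stand for stronger inhibition and higher numbers for weaker inhibition), compound 1 gives only a limit of the assay, > 100000 nM. Compound 2 `COc1ccc2nc(C)cc(OCC(=O)Nc3cccnc3)c2c1`; in this assay compound 2 likewise gives only a limit, > 100000 nM. Compound 3 `COc1ccc2nc(C)cc(OCC(=O)Nc3c(C)cncc3C)c2c1`; in this assay compound 3 gives 12600 nM.

Among the compounds with values here, compound 3 thus holds the only number among the three values, the other two sitting at the limit of > 100000 nM in this assay, at which 2 of the 3 values shown sit. Compound 4 `COc1ccc2nc(C)cc(OCC(=O)NC3CONC3=O)c2c1` differs from compound 3 in that (a group of 6 heavy atoms (3 carbon, 1 nitrogen, 2 oxygen; one five-membered non-aromatic ring with 2 hetero atoms) in place of a group of 8 heavy atoms (7 carbon, 1 nitrogen; one six-membered aromatic ring with 1 hetero atom), on an amide-type nitrogen). Two measured steps are known, an at least 7.9-fold lower number from compound 1 to compound 3 (0.89 log units; beyond the scatter) and an at least 7.9-fold lower number from compound 2 to compound 3 (0.89 log units; beyond the scatter); both start from a limit and so are read only as lower bounds, and both swap one aromatic substituent for another, whereas the change to compound 4 removes the aromatic ring altogether. The expectation is therefore that compound 4 moves back toward weaker inhibition, a step of a 4.8-fold higher number from compound 3 to compound 4 (0.68 log units; beyond the scatter). Compound 4 is estimated at 60000 nM, within 15000 nM to 150000 nM.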

Compound 4, half-maximal inhibitory concentration: > 100000 nM
Compound 4: a limit, no number (the forecaster's own chance of this, stated with the estimate: 55%); middle value at least 1.6-fold (0.22 log units) from the limit.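

In this assay compound 4 gives > 100000 nM as a limit of the assay and not a number, which places it with compounds 1 and 2: the limit of > 100000 nM in this assay, at which 3 of the 4 values shown sit. On the amide-type nitrogen, the five-membered non-aromatic ring in place of 3,5-dimethylpyridin-4-yl gives an at least 7.9-fold higher number from compound 3 to compound 4 (0.89 log units; beyond the scatter), so among these four compounds only 3,5-dimethylpyridin-4-yl yields a number. The steps from compounds 1 and 2 to compound 4 cannot be read. On these data alone, whether an amine, a carboxylic acid or a longer alkyl chain on this nitrogen would yield a number remains open.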